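Swapping the aryl amide cap: an estimate for compound 3

The compounds below may be only part of what the source reports. "The series", "measured", "known", "first", "only" and "open" are said of these compounds alone.

Measured compounds:
- compound 1, `CN(C(=O)NC(=O)c1ccccc1F)c1nc(C(F)(F)F)c(C(=O)N/N=C/c2cc(C(F)(F)F)cc(C(F)(F)F)c2)s1`: 4.47 ug/mL
- compound 2, `CN(C(=O)NC(=O)c1ccc([N+](=O)[O-])cc1)c1nc(C(F)(F)F)c(C(=O)N/N=C/c2ccc([N+](=O)[O-])cc2)s1`: 12.3 ug/mL

In a functional assay on HepG2 cells (Homo sapiens) for inhibition, read by MTT assay, with a stated time of 72 h (a higher number here means a weaker inhibitor, a lower number a stronger inhibitor), compound 1 gives 4.47 ug/mL, the lowest of the two numbers recorded. Compound 2 gives 12.3 ug/mL in this assay, a weaker result that lies beyond the scatter, but the two compounds differ at both ends of the shared core, so their gap cannot be assigned to a single change.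

Compound 3, `CN(C(=O)NC(=O)c1ccc(Cl)cc1Cl)c1nc(C(F)(F)F)c(C(=O)N/N=C/c2cc(C(F)(F)F)cc(C(F)(F)F)c2)s1`, is not yet measured. It differs from compound 1 in one place: 2,4-dichlorophenyl in place of 2-fluorophenyl on a carbonyl carbon. The bis(trifluoromethyl)phenyl hydrazone end of compound 1 is kept unchanged. Among the compounds with values here, with no comparable single step among the measured compounds, the size of this step rests on judgement alone. The change is expected to leave the number close to that of compound 1, with a step of a 1.3-fold lower number from compound 1 to compound 3 (0.11 log units; within the scatter) that stays within the scatter. Compound 3 is estimated at 3.5 ug/mL, between 1.5 ug/mL and 9 ug/mL.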

Compound 3, half-maximal inhibitory concentration: > 100 ug/mL
Compound 3 was reported as a limit; the forecaster's own chance of this, stated with the estimate: 5%; middle value at least 28-fold (1.45 log units) away from the limit.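

In this assay, the aryl group on the carbonyl carbon proves far from a neutral place to vary: with the bis(trifluoromethyl)phenyl hydrazone end kept, putting 2,4-dichlorophenyl in place of 2-fluorophenyl brings an at least 22-fold higher number from compound 1 to compound 3 (1.34 log units; beyond the scatter). Compound 1 and compound 2 could not show this, since they differ at both ends of the shared core and their gap belongs to no single change. The value of compound 3 is a limit and not a number: the limit of > 100 ug/mL in this assay, at which 1 of the 3 values shown sits.

The compounds shown leave open whether this step belongs to the two chlorine atoms together or to a single chlorine on this ring, and how a plain phenyl would read at the same place. They also leave open what an amine or a carboxylic acid on this ring would do in this assay.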